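Bromo to Chloro on the Anilide Ring of Compound 1

The source may report more compounds than this note shows. Statements on the series, on what has been measured and on what is new or still open speak of the compounds shown alone.

Compound 1 `O=C(CSc1nncnc1-c1ccccc1Cl)Nc1ccccc1Br` has the higher of the two numbers measured in an ADME assay on MT4 cells (Homo sapiens) for cytotoxicity, read by MTT assay (on this read-out lower numbers stand for higher toxicity in this test and higher numbers for lower toxicity in this test), giving 73000 nM. Among the measured compounds shown here, its only neighbour, compound 2 `CC(=O)c1ccc(NC(=O)CSc2nncnc2-c2ccccc2Cl)c(Br)c1`, gives 34000 nM in this assay, and the single step measured, a 2.1-fold lower number from compound 1 to compound 2 (0.33 log units; beyond the scatter), comes from an acetyl in place of hydrogen on an aromatic carbon.

Compound 3 `O=C(CSc1nncnc1-c1ccccc1Cl)Nc1ccccc1Cl` is the next compound to be measured. It differs from compound 1 in one place: chloro in place of bromo on an aromatic carbon. For the measured compounds named here, no measured step concerns a halogen exchange; the only step available, the acetyl step from compound 1 to compound 2, was modest and touches a different position, so it gives no direct guidance for the change to compound 3. With one halogen replaced by another of like kind, the step in this assay is expected to lie within the usual scatter, in no particular direction.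

The estimate for compound 3 in this assay is therefore 73000 nM, with a range from 35000 nM to 150000 nM, which means an expected step of no change at the digits printed from compound 1 to compound 3 (within the scatter).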

Compound 3, half-maximal cytotoxic concentration: 90000 nM
The estimate for compound 3 lay 1.2-fold (0.09 log units) below the measured number; measured number inside the range.
By their numbers in this assay, from the lowest: compound 2; then compounds 1 and 3 (each within the scatter of the next).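

In this assay, among the compounds shown here, chloro in place of bromo on an aromatic carbon ortho to a large group gives a 1.2-fold higher number from compound 1 to compound 3 (0.09 log units; within the scatter), so the two halogens cannot be told apart at this place on this read-out, and the first measured step at this position shows no effect of the exchange. For the compounds shown here, until now, the only step available was a 2.1-fold lower number from compound 1 to compound 2 (0.33 log units; beyond the scatter), which came from an acetyl at a different place on the ring and said nothing about the halogen. No measurement here speaks to why bromo and chloro read alike in this test.

The compounds shown cover only these two halogens at this place, so it remains open whether the same flat result would hold for a group of another kind there, such as an amine, a carboxylic acid or a longer chain, or for plain hydrogen. Going by these compounds, it also remains open whether the acetyl step would repeat on the chloro compound, since that step has been read only with bromo in place.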